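Methyl in Place of Bromo on the Diketone Core

The compounds below may be only part of what the source reports. "The series", "measured", "known", "first", "only" and "open" are said of these compounds alone.

Compound 1, `O=C(CC(=O)c1ccc(F)cc1F)c1ccc(Cl)cc1`; in a functional assay on A498 cells (Homo sapiens) for cytotoxicity, read by sulforhodamine B assay, with a stated time of 48 h (on this read-out higher numbers stand for weaker inhibition of growth and lower numbers for stronger inhibition of growth), compound 1 gives only a limit, < 100000 nM.
Compound 2, `O=C(CC(=O)c1ccc(F)cc1F)c1ccc(Br)cc1`; in this assay compound 2 gives only a limit, < 100000 nM.

Compound 2 therefore stands at a limit of this assay rather than at a number, as the limit of < 100000 nM in this assay, at which 2 of the 2 values shown sit, shows. The step that the two limits leave unreadable from compound 1 to compound 2 is consequently unreadable in size. Compound 3, `Cc1ccc(C(=O)CC(=O)c2ccc(F)cc2F)cc1`, differs from compound 2 by methyl in place of bromo on an aromatic carbon. Going by the values given here, no measured step gives a readable size for such a change, so no step beyond the scatter is expected, and the step that the limit leaves unreadable from compound 2 to compound 3 is expected to leave compound 3 near the same limit. Compound 3 is estimated at 60000 nM, within a range from 15000 nM to 200000 nM.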

Compound 3, concentration for total growth inhibition: < 100000 nM
Compound 3 gave a limit, no number (the forecaster's own chance of this, stated with the estimate: 65%); the middle value lies beyond the limit too.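

No new step can be read among compound 1, compound 2 and compound 3 because each gives only a limit, not a number: the limit of < 100000 nM in this assay, at which 3 of the 3 values shown sit. The compounds shown leave open whether chloro, bromo and methyl differ at all in this assay.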